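Para substituent on the aniline: ester in place of ethyl

This account rests on a few compounds, and the source may have more. Where it says the series, first, only, none or still open, it means among the compounds named here.

Compound 3 `CCc1ccc(Nc2ccc3c(c2)C(=O)N(C2CCC(=O)NC2=O)C3=O)cc1` gives 5% in an assay on FRT-Jurkat cells for inhibition of nuclear factor NF-kappa-B complex (Homo sapiens), read by flow cytometry, with a stated time of 24 h, tested at 10 uM (on this read-out higher numbers stand for more inhibition at the one concentration tested (going by the name of the read-out) and lower numbers for less inhibition), level with compound 1 `Cc1ccc(Nc2ccc3c(c2)C(=O)N(C2CCC(=O)NC2=O)C3=O)cc1` at 5% (no change at the digits printed from compound 1 to compound 3 (within the scatter)), and together they sit lowest of the three; compound 2 `COc1ccc(Nc2ccc3c(c2)C(=O)N(C2CCC(=O)NC2=O)C3=O)cc1` at 29% stands apart (a number 24 percentage points lower from compound 2 to compound 3 (beyond the scatter)). Compound 4 `CCOC(=O)c1ccc(Nc2ccc3c(c2)C(=O)N(C2CCC(=O)NC2=O)C3=O)cc1` carries the change (ethoxycarbonyl in place of ethyl on an aromatic carbon). The relevant steps are the two swaps at the same aromatic carbon: a number 24 percentage points higher from compound 1 to compound 2 (beyond the scatter) and a number 24 percentage points lower from compound 2 to compound 3 (beyond the scatter), both modest and in opposite directions, so a group entering there can move the number either way. With an oxygen-bearing group entering, as in compound 2 with 29%, a modest rise is expected for compound 4, estimated at 20% within 0% to 45%. The expected step is a number 15 percentage points higher from compound 3 to compound 4 (beyond the scatter).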

Compound 4, a percentage reported as inhibition, at one concentration (the size of the read-out at that concentration, not a potency): 5%
Compound 4: middle estimate off by 15 percentage points, on the high side; the range from low to high includes it.
By their numbers in this assay, from the lowest: compounds 1, 3 and 4 (each within the scatter of the next); then compound 2.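

In this assay, ethoxycarbonyl at this aromatic carbon gives no change at the digits printed from compound 3 to compound 4 (within the scatter) and no change at the digits printed from compound 1 to compound 4 (within the scatter), so the larger group with two hydrogen-bond acceptors does not separate from the alkyl groups. The remaining step, a number 24 percentage points lower from compound 2 to compound 4 (beyond the scatter), shows that oxygen in the entering group does not by itself carry the higher number of the methoxy group. Nothing available explains the difference between methoxy and ethoxycarbonyl at this carbon.

Open, from the compounds shown here alone, is whether ethoxy, a longer alkoxy chain, would stay with methoxy. An amine or a carboxylic acid at this carbon also remains untested among the compounds shown here.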